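Compound 3 to compound 4: a methyl on the chain

The compounds below may be only part of what the source reports. "The series", "measured", "known", "first", "only" and "open" are said of these compounds alone.

In a functional assay on MDA-MB-231 cells (Homo sapiens) for cytotoxicity, read by MTT assay, with a stated time of 24 h (on this read-out lower numbers stand for stronger inhibition and higher numbers for weaker inhibition), three compounds have been measured so far, and their numbers lie close together. Compound 1 (`C[C@@H](N)C(=O)NCc1nnc(-c2ccccc2)o1`) gives 230 nM, and compound 2 (`C[C@@H](N)C(=O)NCc1nnc(-c2ccc(F)cc2)o1`) gives 247 nM. Compound 3 (`Cc1ccc(-c2nnc(CNC(=O)CN)o2)cc1`) gives 260 nM, which is within the scatter of both others.

Compound 4 (`Cc1ccc(-c2nnc(CNC(=O)[C@@H](C)N)o2)cc1`) differs from compound 3 in one place: methyl in place of hydrogen on a saturated chain carbon bound to an amine nitrogen and a carbonyl carbon. This is methyl in place of hydrogen on a saturated chain carbon bound to an amine nitrogen and a carbonyl carbon, so aminomethyl becomes 1-aminoethyl.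

Within the data shown here, no measured step tests this change directly. The only one available is a 1.1-fold higher number from compound 1 to compound 2 (0.03 log units; within the scatter), a fluoro in place of hydrogen on an aromatic carbon, and it stays within the scatter. Indirect support comes from the two compounds that already carry the 1-aminoethyl group: compound 1 at 230 nM and compound 2 at 247 nM stay within the scatter of compound 3 at 260 nM. With so few compounds, this is a weak guide, but no shift beyond the scatter is expected.

The expected size of the change is a 1.1-fold lower number from compound 3 to compound 4 (0.03 log units; within the scatter). For compound 4 the estimated value is 240 nM, with an expected range from 130 nM to 440 nM.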

Compound 4, half-maximal inhibitory concentration: 254 nM
For compound 4 the middle estimate is 1.1-fold (0.02 log units) below the measured one; measured number inside the range.
By their numbers in this assay, from the lowest: compounds 1, 2, 4 and 3 (each within the scatter of the next).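

In this assay, the step (a 1.0-fold lower number from compound 3 to compound 4 (0.01 log units; within the scatter)) gives a direct reading of methyl in place of hydrogen on the saturated chain carbon bound to an amine nitrogen and a carbonyl carbon, and aminomethyl and 1-aminoethyl cannot be told apart here. Compound 4 also adds two readings on an aromatic carbon, methyl in place of hydrogen (a 1.1-fold higher number from compound 1 to compound 4 (0.04 log units; within the scatter)) and methyl in place of fluoro (a 1.0-fold higher number from compound 2 to compound 4 (0.01 log units; within the scatter)), so that, together with the earlier fluoro step, hydrogen, fluoro and methyl at that place cannot be told apart in this assay either. No supporting measurement bears on why these steps stay so small.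

On the chain carbon, the compounds shown carry only hydrogen or methyl, so the outcome with a longer chain such as ethyl, or with a phenyl group, stays open. As far as these compounds go, on the aromatic carbon, the outcome with a methoxy group, a nitrile or a carboxylic acid also stays open, as does that of a hydroxyl group in place of the amine, which all four compounds keep.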